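A new group on the chain of compound 3

This account rests on a few compounds, and the source may have more. Where it says the series, first, only, none or still open, it means among the compounds named here.

Measured in a functional assay on HCT-116 cells (Homo sapiens) for antiproliferative activity, read by MTT assay, with a stated time of 48 h; a higher number here means a weaker inhibitor, a lower number a stronger inhibitor:
- Compound 1 `CC(CCO)n1cnc2c(Cl)ncnc21`: > 50000 nM (a limit)
- Compound 2 `CCCCCCCCC[C@H](CCOS(C)(=O)=O)n1cnc2c(Cl)ncnc21`: 9480 nM
- Compound 3 `CCCCCCCCCC(CCOS(C)(=O)=O)n1cnc2c(Cl)ncnc21`: 5440 nM

The value of compound 1 is a limit of this assay and not a number. That leaves two real numbers, and compound 3, at 5440 nM, cannot be told apart from the other one: the data show a 1.7-fold lower number from compound 2 to compound 3 (0.24 log units; within the scatter). That step concerns only (the fact that one of compounds 2 and 3 is drawn with a defined configuration and the other without, at the place where they differ), so it gives no guide to a change of group.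

Compound 4 `CCCCCCCCCC(CCn1cc(-c2ccccc2)nn1)n1cnc2c(Cl)ncnc21` alters compound 3 in one place: 4-phenyl-1H-1,2,3-triazol-1-yl in place of (methylsulfonyl)oxy on a saturated chain carbon, three bonds along the chain from an aromatic nitrogen. Among the measured compounds shown here, no measured step touches this place, so neither its size nor its direction can be read from the data. For the measured compounds named here, with nothing pointing either way, no step clearly beyond the scatter is expected, although real uncertainty remains. The estimated change is a 1.3-fold higher number from compound 3 to compound 4 (0.11 log units; within the scatter). For compound 4 the expected value is 7000 nM, with an estimated range from 2000 nM to 25000 nM.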

Compound 4, half-maximal inhibitory concentration: 13500 nM
Compound 4: the middle estimate sits 1.9-fold (0.29 log units) below what was measured; measured number inside the range.
By their numbers in this assay, from the lowest: compounds 3, 2 and 4 (each within the scatter of the next, the first and the last beyond it). At a limit, above all of these: compound 1.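

In this assay, the place on a saturated chain carbon, three bonds along the chain from an aromatic nitrogen, now has its first measured step: 4-phenyl-1H-1,2,3-triazol-1-yl in place of (methylsulfonyl)oxy gives a 2.5-fold higher number from compound 3 to compound 4 (0.39 log units; beyond the scatter). The step is modest, but it shows that the number does respond to the group at this place, and that a group with two aromatic rings can stand there while compound 4 still gives a real number and not a limit. Nothing measured here explains why the number moves.

This one swap changes the atoms and the rings together, so it leaves open whether the triazole or the phenyl ring goes with the step. It also leaves open what a plain amine, a carboxylic acid or a triazole without the phenyl ring would give at this place.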